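This account rests on a few compounds, and the source may have more. Where it says the series, first, only, none or still open, it means among the compounds named here.

Compound 1, `CS(=O)(=O)N1CC(CCl)c2ccc(OCc3ccccc3)cc21`, gives 6.32 ug/mL in a functional assay on KB cells (Homo sapiens), read by crystal violet staining; on this read-out higher numbers stand for weaker inhibition and lower numbers for stronger inhibition. Compound 2, `CS(=O)(=O)N1CC(CCl)c2ccc(O)cc21`, gives 4.24 ug/mL. Compound 3, `CS(=O)(=O)N1CC(CCl)c2cc(Br)c(O)cc21`, gives 3.8 ug/mL.

All three compounds rest on a shared core and differ from one another in only two spots. Compound 2 and compound 3 differ by bromo in place of hydrogen on an aromatic carbon; that step measured a 1.1-fold lower number from compound 2 to compound 3 (0.05 log units; within the scatter). Compound 2 and compound 1 differ by benzyl in place of hydrogen on an oxygen on an aromatic ring; that step measured a 1.5-fold higher number from compound 2 to compound 1 (0.17 log units; within the scatter). Compound 4, `CS(=O)(=O)N1CC(CCl)c2cc(Br)c(OCc3ccccc3)cc21`, has not yet been measured. It differs from compound 3 by benzyl in place of hydrogen on an oxygen on an aromatic ring, the same change already seen between compound 2 and compound 1, at the same place. Because a 1.5-fold higher number from compound 2 to compound 1 (0.17 log units; within the scatter), a similarly small step of a 1.5-fold higher number from compound 3 to compound 4 (0.18 log units; within the scatter) is expected. For compound 4 the estimate is 5.7 ug/mL, with a likely range from 3 ug/mL to 11 ug/mL.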

Compound 4, half-maximal inhibitory concentration: 6.18 ug/mL
Compound 4: middle estimate off by 1.1-fold (0.04 log units), on the low side; the measured number falls inside the stated range.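

In this assay, benzyl in place of hydrogen on the oxygen gives a 1.6-fold higher number from compound 3 to compound 4 (0.21 log units; within the scatter), which matches the same change on the core without bromo: the same change on two cores in this assay, a 1.5-fold higher number (0.17 log units; within the scatter) from compound 2 to compound 1 and a 1.6-fold higher number (0.21 log units; within the scatter) from compound 3 to compound 4, 1.1-fold (0.04 log units) apart, within the scatter of two such steps. Bromo in place of hydrogen on an aromatic carbon gives a 1.0-fold lower number from compound 1 to compound 4 (0.01 log units; within the scatter), and this also matches its earlier step: the same change on two cores in this assay, a 1.1-fold lower number (0.05 log units; within the scatter) from compound 2 to compound 3 and a 1.0-fold lower number (0.01 log units; within the scatter) from compound 1 to compound 4, 1.1-fold (0.04 log units) apart, within the scatter of two such steps. Each change thus stays small on both cores tested, but since every step lies within the scatter, this does not show that either change has a real effect, or that such agreement would hold for a change with a larger step or on other cores.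

As far as these compounds go, it remains open whether a longer chain ending in an amine or a carboxylic acid on that oxygen would shift the number beyond the scatter. The same question stands for a nitrile in place of bromo.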